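Compound 3: methyl in place of cyclohexyl

A few compounds are considered here, and "the series" means these few. Any claim that something is new, unique, unknown or untested is made for them only; others in the source may bear on it.

Compound 1 `CC(C)n1nc(-c2ccon2)c2c(N)ncnc21` gives > 10000 nM in an ADME assay on BaF3 cells (Mus musculus) for cytotoxicity, read by MTT assay, with a stated time of 48 h (a higher number here means a weaker inhibitor of growth, a lower number a stronger inhibitor of growth), which is a limit of the assay and not a number. Compound 2 `Nc1ncnc2c1c(-c1cc(C3CC3)on1)nn2C1CCCCC1` gives > 10000 nM in this assay, again a limit and not a number. Within the data shown here, the series so far reads: the limit of > 10000 nM in this assay, at which 2 of the 2 values shown sit. Compound 3 `Cn1nc(-c2cc(C3CC3)on2)c2c(N)ncnc21` has methyl in place of cyclohexyl on an aromatic nitrogen, two ring bonds from the ring atom that bears the 5-cyclopropyl-1,2-oxazol-3-yl group: methyl in place of cyclohexyl on an aromatic nitrogen. Among the measured compounds shown here, no measured step in this assay shows what such a change does. Compound 2, at > 10000 nM, offers only a limit as its anchor. The expected step, a step that the limit leaves unreadable from compound 2 to compound 3, is none beyond the scatter, with no direction expected. For compound 3 the estimate is 12000 nM, with an expected range from 5000 nM to 30000 nM.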

Compound 3, concentration for 50% growth inhibition: > 10000 nM
Compound 3 ended at the assay's limit (the forecaster's own chance of this, stated with the estimate: 80%); the middle value is on the limit's open side.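

The step from compound 2 to compound 3, methyl in place of cyclohexyl on an aromatic nitrogen, cannot be read in this assay, as both compounds give only a limit: the limit of > 10000 nM in this assay, at which 3 of the 3 values shown sit.

The compounds shown leave open how strongly compound 1, compound 2 or compound 3 inhibits growth, and in which direction this change acts.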